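Working notes: from compound 2 to compound 4

A few compounds are considered here, and "the series" means these few. Any claim that something is new, unique, unknown or untested is made for them only; others in the source may bear on it.

Measured in a functional assay on MGC-803 cells (Homo sapiens) for antiproliferative activity, read by MTT assay, with a stated time of 72 h; a higher number here means a weaker inhibitor, a lower number a stronger inhibitor:
- Compound 1 `Cc1ccc(C(C)C)c(OCCSC(=S)N[C@H]2CCOC2=O)c1`: 43400 nM
- Compound 2 `O=C(COc1ccc(C(=O)/C=C/c2ccc(F)cc2)cc1)N[C@H]1CCOC1=O`: > 64000 nM (a limit, not a number)
- Compound 3 `C=CCc1ccc(OCCSC(=S)N[C@H]2CCOC2=O)c(OC)c1`: 27900 nM

Compound 2 is known only through a limit, > 64000 nM. Compound 4 `O=C(COc1ccc(C(=O)/C=C/c2ccccc2Br)cc1)N[C@H]1CCOC1=O` is not yet measured. It carries 2-bromophenyl in place of 4-fluorophenyl on a double-bonded chain carbon bound to a double-bonded chain carbon.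

For the measured compounds named here, compound 1 and compound 3 differ from compound 2 in more than one place, so no measured step bears on this change. In this assay, no step beyond the usual scatter is expected, and no direction can be argued from these data. This expectation rests on compound 2 alone, with its limit of > 64000 nM. A limit may well be reported again for compound 4.

The estimated step runs an at least 1.0-fold lower number from compound 2 to compound 4 (0.02 log units; that floor lies within the scatter). For compound 4 the estimate is 60000 nM, with an expected range of 25000 nM to 130000 nM.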

Compound 4, half-maximal inhibitory concentration: 12200 nM
Compound 4: the middle estimate sits 4.9-fold (0.69 log units) above what was measured, and the stated range ends above it.
By their numbers in this assay, from the lowest: compound 4; then compounds 3 and 1 (each within the scatter of the next). At a limit, above all of these: compound 2.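

In this assay, the aryl group on a double-bonded chain carbon bound to a double-bonded chain carbon proves able to move the read-out: 2-bromophenyl in place of 4-fluorophenyl gives an at least 5.2-fold lower number from compound 2 to compound 4 (0.71 log units; beyond the scatter). The earlier compounds shown here offered no measured step at this place, and compound 4 shows that a change confined to this aryl group, with the rest of compound 2 kept, is enough to go beyond the scatter. Compound 2 is known only through a limit, so the step is a floor and its true size cannot be read: the limit of > 64000 nM in this assay, at which 1 of the 4 values shown sits.

The exchange alters both the halogen and its place on the ring, and the compounds shown do not separate the two. Also open, as far as these compounds go, is how a plain phenyl, or a phenyl bearing a nitrile or an amine, would compare with compound 4.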